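Replacing a hydrazide ether with an ethyl acrylate

A few compounds are considered here, and "the series" means these few. Any claim that something is new, unique, unknown or untested is made for them only; others in the source may bear on it.

The series rests on a shared core that carries a large bicyclic aromatic group and a variable side chain. Among the measured compounds shown here, compound 1 `CNC(=O)/C=C/c1ccncc1-c1ccc2ccccc2c1` is the only member with a number: in an assay on a protein complex for inhibition of CDK8/Cyclin C (Homo sapiens), with a stated time of 1 h (a higher number here means a weaker inhibitor, a lower number a stronger inhibitor), compound 1 gives 12.4 nM. Compound 2 `O=C(O)[C@@H]1CCCN1C(=O)/C=C/c1ccncc1-c1ccc2ccccc2c1` carries a cyclic acid on its side chain, and in this assay compound 2 gives "not determined" (no result reported). Compound 3 `NNC(=O)COc1ccncc1-c1ccc2ccccc2c1` likewise has no result, since in this assay compound 3 gives "not determined" (no result reported). Compound 3 therefore stands nowhere on the numbers shown, and one further compound shares that position.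

Compound 4 `CCOC(=O)/C=C/c1ccncc1-c1ccc2ccccc2c1` arises from compound 3 by the change (2-(ethoxycarbonyl)ethenyl in place of (aminocarbamoyl)methoxy on an aromatic carbon). For the measured compounds named here, no measured pair shows what such a swap does, so the size and direction of the step from compound 3 to compound 4 in this assay cannot be read from the data. Compound 4 does, however, resemble compound 1 more closely than compound 3 does. Because compound 1 gives 12.4 nM, compound 4 is expected to land near it, at an estimated 40 nM with a range of 8 nM to 300 nM.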

Compound 4, half-maximal inhibitory concentration: 53.3 nM
The estimate for compound 4 lay 1.3-fold (0.12 log units) below the measured number; the range from low to high includes it.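

With the 2-(ethoxycarbonyl)ethenyl group in place, the side chain can be compared at its carbonyl end: in this assay, ethoxy in place of methylamino on the carbonyl carbon gives a 4.3-fold higher number from compound 1 to compound 4 (0.63 log units; beyond the scatter) as a modest step. Compound 4 at 53.3 nM remains a measurable inhibitor, so this position tolerates the ester in place of the amide, with some loss of strength. Nothing measured here accounts for the difference.

Among the compounds shown here, compound 2 and compound 3 have no number, so no step involving either can be read. Ethoxy differs from methylamino both in the atom joined to the carbonyl and in the length of its chain, and the compounds shown do not separate these two changes; a methoxy or an ethylamino group on the same carbonyl would tell them apart.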